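The source may hold more compounds than are shown below. What is called first, only, known or untested is meant among the compounds shown, and "the series" means these compounds.

Measured so far in an assay on PMNL cells for inhibition of Polyunsaturated fatty acid 5-lipoxygenase (Homo sapiens), read by HPLC, with stated times of 5 min and 15 min; on this read-out lower numbers stand for stronger inhibition and higher numbers for weaker inhibition:
Compound 1, `COc1cc(/C=C/C(=O)OCCc2ccccc2F)cc(OC)c1O`, gives 240 nM.
Compound 2, `COc1cc(/C=C/C(=O)OCCc2ccccc2C)cc(OC)c1O`, gives 240 nM.
Compound 3, `COc1cccc(CCOC(=O)/C=C/c2cc(OC)c(O)c(OC)c2)c1`, gives 210 nM.

Compound 3 carries the lowest of the three numbers, but its gaps to the other two, a 1.1-fold lower number from compound 1 to compound 3 (0.06 log units; within the scatter) and a 1.1-fold lower number from compound 2 to compound 3 (0.06 log units; within the scatter), sit within the scatter, as does no change at the digits printed from compound 1 to compound 2 (within the scatter), so the three compounds cannot be separated on these data.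

Compound 4, `CCCOC(=O)/C=C/c1cc(OC)c(O)c(OC)c1`, differs from compound 3 by methyl in place of 3-methoxyphenyl on a saturated chain carbon, two bonds along the chain from an oxygen next to a carbonyl group. The measured steps that touch this part of the molecule all swap one aromatic group for another at the same chain position, and none of them moved the read-out beyond the scatter. Among the compounds with values here, no measured step removes the aromatic ring altogether, so the present change reaches past what the three compounds show. The varied aryl groups were interchangeable, so a large shift seems unlikely. Some loss is allowed for all the same: the group that leaves carries the aromatic ring, and the one that enters has no ring.

Compound 4 is therefore expected to give about 400 nM in this assay, within 150 nM to 1500 nM. The expected step is a 1.9-fold higher number from compound 3 to compound 4 (0.28 log units; within the scatter).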

Compound 4, half-maximal inhibitory concentration: 710 nM
The estimate for compound 4 lay 1.8-fold (0.25 log units) below the measured number; the measured number falls inside the stated range.
By their numbers in this assay, from the lowest: compounds 3, 1 and 2 (each within the scatter of the next); then compound 4.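

In this assay this place on a saturated chain carbon, two bonds along the chain from an oxygen next to a carbonyl group, proves sensitive to the group it carries: there is a 3.4-fold higher number from compound 3 to compound 4 (0.53 log units; beyond the scatter) with methyl in place of 3-methoxyphenyl, a 3.0-fold higher number from compound 2 to compound 4 (0.47 log units; beyond the scatter) with methyl in place of 2-methylphenyl, and a 3.0-fold higher number from compound 1 to compound 4 (0.47 log units; beyond the scatter) with methyl in place of 2-fluorophenyl. All three steps lie beyond the scatter and are modest, whereas the swaps of one aromatic group for another stayed within it, so among these four compounds only the change from an aromatic group to methyl moves the read-out. No independent measurement bears on why this shift occurs.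

The compounds shown cannot separate the loss of the aromatic ring from the loss of heavy atoms, since methyl differs from the aromatic groups in both respects. As far as these compounds go, a cyclohexyl group or a longer chain such as pentyl at this place would bear on that question, and how a pyridine ring or an amine would fare here also remains open.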